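Extending the alkyl chain on an aryl vinyl ketone

The source may hold more compounds than are shown below. What is called first, only, known or untested is meant among the compounds shown, and "the series" means these compounds.

compound 1 `C=CC(=O)c1ccc(CCCC)cc1`: 66000 nM
compound 2 `C=CC(=O)c1ccc(CCCCCCC)cc1`: 10500 nM

Two measured compounds share one core and differ only in the length of the chain on the aromatic ring. In an in vitro assay on BL21-DE3 cells for displacement of a labelled ligand from thyroid hormone receptor beta (Homo sapiens), read by fluorescence polarization (on this read-out higher numbers stand for weaker inhibition and lower numbers for stronger inhibition), compound 1 gives 66000 nM. In the same setting compound 2 gives 10500 nM. Going by the values given here, the one measured step between them is a 6.3-fold lower number from compound 1 to compound 2 (0.80 log units; beyond the scatter). Among the compounds with values here, compound 2 therefore stands at the lower of the two numbers, and compound 1 is its only neighbour.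

Compound 3 `C=CC(=O)c1ccc(CCCCCCCC)cc1` takes the chain one carbon further: methyl in place of hydrogen on a saturated chain carbon, seven bonds along the chain from an aromatic carbon. Within the data shown here, the only step that bears on this is the lengthening from compound 1 to compound 2, which added three carbons to the same chain and lowered the number by a modest amount beyond the scatter. The change to compound 3 is smaller and of the same kind, so a smaller step in the same direction is expected in this assay, quite possibly one that does not clear the scatter. The step from compound 2 to compound 3 is estimated as a 1.6-fold lower number from compound 2 to compound 3 (0.21 log units; within the scatter). Compound 3 is accordingly expected to give 6500 nM, with a range from 2500 nM to 20000 nM.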

Compound 3, half-maximal inhibitory concentration: 11400 nM
Estimate against measurement, compound 3: 1.8-fold (0.24 log units) below; measured number inside the range.
By their numbers in this assay, from the lowest: compounds 2 and 3 (each within the scatter of the next); then compound 1.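

In this assay, a methyl in place of hydrogen on a saturated chain carbon, seven bonds along the chain from an aromatic carbon, gives a 1.1-fold higher number from compound 2 to compound 3 (0.04 log units; within the scatter), so compound 2 and compound 3 cannot be told apart, and this one added carbon has no effect that can be read. The longer chain of compound 3 still keeps a clear distance from the shorter chain of compound 1, at a 5.8-fold lower number from compound 1 to compound 3 (0.76 log units; beyond the scatter), a step of much the same size as a 6.3-fold lower number from compound 1 to compound 2 (0.80 log units; beyond the scatter), so among these three compounds the whole of the lowering is already present in compound 2 and the chain's effect does not continue through compound 3. Nothing at hand speaks to the reason for this result.

From the compounds shown here alone, whether a still longer chain would leave the number level, lower it again or raise it remains open. So does what a carboxylic acid or an amine at the end of the chain would do in this assay, since the compounds shown carry only plain alkyl chains on the shared core.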